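From 4-chlorophenyl to 4-methoxyphenyl at the assay limit

This account rests on a few compounds, and the source may have more. Where it says the series, first, only, none or still open, it means among the compounds named here.

In a functional assay on KB cells (Homo sapiens) for antiproliferative activity, read by MTT assay, with a stated time of 48 h (on this read-out higher numbers stand for weaker inhibition and lower numbers for stronger inhibition), compound 1 `Cn1cc(C2=C(c3nn(CCCn4cncn4)c4ncccc34)C(=O)NC2=O)c2ccccc21` gives > 100000 nM, which is a limit. Compound 3 `CN(C)CCCn1nc(C2=C(c3cn(C)c4ccccc34)C(=O)NC2=O)c2cccnc21` gives > 100000 nM, also a limit. Compound 2 `Cn1cc(C2=C(c3nn(CCCN4CCCCC4)c4ncccc34)C(=O)N(c3ccc(Cl)cc3)C2=O)c2ccccc21` gives > 100000 nM, again a limit and not a number.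

Compound 4 `COc1ccc(N2C(=O)C(c3cn(C)c4ccccc34)=C(c3nn(CCCN4CCCCC4)c4ncccc34)C2=O)cc1` carries one change from compound 2: methoxy in place of chloro on an aromatic carbon. This places methoxy in place of chloro on an aromatic carbon, para to a large group. Among the compounds with values here, the one measured step is a step that the two limits leave unreadable from compound 1 to compound 3, and it does not involve this position. Within the data shown here, the series so far rests on (the limit of > 100000 nM in this assay, at which 3 of the 3 values shown sit). No step beyond the scatter and no direction can be expected in this assay. The expected step is a number no higher from compound 2 to compound 4 (the limit leaves the size open). For compound 4 the estimate is 100000 nM, within an estimated range of 30000 nM to 300000 nM.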

Compound 4, half-maximal inhibitory concentration: 44000 nM
Compound 4: the middle estimate sits 2.3-fold (0.36 log units) above what was measured; low and high end bracket the measured number.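

In this assay, the 4-chlorophenyl to 4-methoxyphenyl change gives an at least 2.2-fold lower number from compound 2 to compound 4 (0.35 log units; beyond the scatter), so this position, on an aromatic carbon para to a large group, can move the read-out. Compound 4 gives 44000 nM, a number rather than a limit. The other compounds shown stay at a limit: the limit of > 100000 nM in this assay, at which 3 of the 4 values shown sit.

As far as these compounds go, the full size of the step stays open, with compound 2 held at a limit. Also open, from the compounds shown here alone, is how an amine, a hydroxy group or a longer ethoxy chain would read at this position.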